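The compounds below may be only part of what the source reports. "The series", "measured", "known", "first", "only" and "open" are said of these compounds alone.

Working notes on the series.

Of the compounds shown here, three sharing one core have been measured in a functional assay on HCT-116 cells (Homo sapiens) for antiproliferative activity, read by MTT assay, with a stated time of 48 h; on this read-out lower numbers stand for stronger inhibition of growth and higher numbers for weaker inhibition of growth. Compound 1 `CCCCN(Cc1ccc(C(=O)NO)cc1)c1ncc(-c2ccc(C)cc2)s1` gives 8780 nM. Compound 2 `CCCCCCN(Cc1ccc(C(=O)NO)cc1)c1ncc(-c2ccc(C)cc2)s1` gives 4850 nM, a step of a 1.8-fold lower number from compound 1 to compound 2 (0.26 log units; within the scatter). Compound 3 `Cc1ccc(OCCCN(Cc2ccc(C(=O)NO)cc2)c2ncc(-c3ccc(C)cc3)s2)cc1` gives 12600 nM, the highest of the three numbers; against compound 1 the step is a 1.4-fold higher number from compound 1 to compound 3 (0.16 log units; within the scatter), and only against compound 2 does the gap exceed the scatter, at a 2.6-fold higher number from compound 2 to compound 3 (0.41 log units; beyond the scatter).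

The next compound is compound 4 `Cc1ccc(-c2cnc(N(Cc3ccccc3)Cc3ccc(C(=O)NO)cc3)s2)cc1`. Compared with compound 3 the change is phenyl in place of 2-(4-methylphenoxy)ethyl on a saturated chain carbon bound to a nitrogen on an aromatic ring. Going by the values given here, the steps that bear on it are the two that swap the group on the chain nitrogen of compound 3, a 1.4-fold higher number from compound 1 to compound 3 (0.16 log units; within the scatter) and a 2.6-fold higher number from compound 2 to compound 3 (0.41 log units; beyond the scatter), together with the chain lengthening a 1.8-fold lower number from compound 1 to compound 2 (0.26 log units; within the scatter); none of them moved the number far, and the largest of them was only modest. Replacing the 4-methylphenoxy-bearing chain with a shorter benzyl group is therefore expected to give at most a small shift, probably toward a lower number, since the shorter butyl chain of compound 1 sits at 8780 nM.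

For compound 4 the estimate is 7500 nM, with a range from 3000 nM to 18000 nM, which means an expected step of a 1.7-fold lower number from compound 3 to compound 4 (0.23 log units; within the scatter).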

Compound 4, concentration for 50% growth inhibition: 48800 nM
For compound 4 the middle estimate is 6.5-fold (0.81 log units) below the measured one; measured number above the stated range.
By their numbers in this assay, from the lowest: compounds 2, 1 and 3 (each within the scatter of the next, the first and the last beyond it); then compound 4.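

At the saturated chain carbon bound to the nitrogen on the aromatic ring, compounds 1, 2 and 3 left the number in this assay within a narrow band, and only compounds 2 and 3 lay beyond the scatter of each other. Benzyl in compound 4 is the first group here to separate from all the others, and compound 4 is the weakest of the four, with a 3.9-fold higher number from compound 3 to compound 4 (0.59 log units; beyond the scatter), a 5.6-fold higher number from compound 1 to compound 4 (0.74 log units; beyond the scatter) and a 10-fold higher number from compound 2 to compound 4 (1.00 log units; beyond the scatter). The leaving 3-(4-methylphenoxy)propyl and the entering benzyl each carry one six-membered aromatic ring of carbon only, so the presence of such a ring does not by itself set the number, and nothing available accounts for the loss.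

Open, as far as these compounds go, is whether the number recovers when the aromatic ring stands further out on a chain, as in 2-phenylethyl or 3-phenylpropyl, or whether only the benzyl arrangement carries this penalty. Also open, from the compounds shown here alone, is how a chain ending in an amine or a carboxylic acid would behave at this place on the shared core.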